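Removing One Methoxy Group from a Cytotoxicity Series

A few compounds are considered here, and "the series" means these few. Any claim that something is new, unique, unknown or untested is made for them only; others in the source may bear on it.

Compound 1, `COc1ccc(-c2cc(/C=C/C(=O)c3ccc(N)cc3)[nH]n2)cc1`, gives 96% in a functional assay on OVCAR-8 cells (Homo sapiens) for cytotoxicity, read by sulforhodamine B assay, with a stated time of 48 h, tested at 0.01 uM; a higher number here means a weaker effect of the compound at the concentration tested, a lower number a stronger effect.
Compound 2, `COc1ccc(-c2cc(/C=C/C(=O)c3ccc(N)cc3)[nH]n2)cc1OC`, gives 98% in this assay.
Compound 3, `COc1cc(C(=O)/C=C/c2cc(-c3cc(OC)c(OC)c(OC)c3)n[nH]2)cc(OC)c1OC`, gives 100% in this assay.

All three measured values lie within the scatter of one another, so none of these compounds can be called stronger or weaker than the others in this assay at the concentration used. Within the data shown here, the one comparison that changes a single place is the step from compound 2 to compound 1: hydrogen in place of methoxy on an aromatic carbon, giving a number 2 percentage points lower from compound 2 to compound 1 (within the scatter). The difference between the core of compound 2 and the core of compound 3 is not broken down here.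

Compound 4, `COc1ccc(-c2cc(/C=C/C(=O)c3cc(OC)c(OC)c(OC)c3)[nH]n2)cc1OC`, has not yet been measured. It is reached from compound 3 by hydrogen in place of methoxy on an aromatic carbon. Among the measured compounds shown here, this is the same kind of change as the one from compound 2 to compound 1, though the surroundings differ: in compound 3 the carbon that loses its methoxy group is also meta to a methoxy group, which is not so in compound 2.

Because the earlier change gave a number 2 percentage points lower from compound 2 to compound 1 (within the scatter), the step from compound 3 to compound 4 in this assay is expected to be similar, about a number 2 percentage points lower from compound 3 to compound 4 (within the scatter). Compound 4 is therefore estimated at 98%, with a likely range from 90% to 105%.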

Compound 4, a percentage reported as activity, at one concentration (the size of the read-out at that concentration, not a potency): 100%
The estimate for compound 4 lay 2 percentage points below the measured number, and the stated range covers the measured number.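

In this assay, putting hydrogen in place of methoxy on an aromatic carbon gave no change at the digits printed from compound 3 to compound 4 (within the scatter). Set beside the same change on the other core, the two steps agree as far as this assay can tell: the same change on two cores in this assay, a number 2 percentage points lower (within the scatter) from compound 2 to compound 1 and no change at the digits printed (within the scatter) from compound 3 to compound 4, 2 percentage points apart, within the scatter of two such steps. This shows that, on these two cores and at this one concentration, the change carries over in the limited sense that it leaves no readable mark on either of them, but it does not show that the methoxy group is without importance, since a step that stays within the scatter cannot reveal a small effect, and a larger one might appear only at other concentrations.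

The compounds shown leave open whether any other group on that aromatic carbon, such as a hydroxyl group, a chlorine atom or a carboxylic acid, would give a number clearly different from those of compound 3 and compound 4. They also leave open how removing a methoxy group would read on a core whose number already lies well below those seen here, where a step would have room to show.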